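Replacing methyl with chloro on the aryl ring

The compounds below may be only part of what the source reports. "The series", "measured", "known", "first", "only" and "open" are said of these compounds alone.

Compound 1 `Cc1nc2c(cnn2CC2CCCCC2)c(=O)n1-c1ccc(Cl)cc1` carries a cyclohexylmethyl group on the aromatic nitrogen. In an in vitro functional assay on cells for antagonist activity at metabotropic glutamate receptor 1 (Homo sapiens), read by FLIPR and calcium flux (a higher number here means a weaker inhibitor, a lower number a stronger inhibitor), compound 1 sits at a limit, > 100000 nM (the limit of > 100000 nM in this assay, at which 1 of the 3 values shown sits). Compound 2 `Cc1ccccc1-n1ncc2c(=O)n(-c3ccc(Cl)cc3)c(C)nc21`, with 2-methylphenyl there, gives 350 nM in this assay, and compound 3 `Cc1cccc(-n2ncc3c(=O)n(-c4ccc(Cl)cc4)c(C)nc32)c1`, with 3-methylphenyl, gives 180 nM. The aryl compounds lie far from compound 1: an at least 280-fold lower number from compound 1 to compound 2 (2.45 log units; beyond the scatter) and an at least 550-fold lower number from compound 1 to compound 3 (2.74 log units; beyond the scatter). Compound 3 holds the lower of the two numbers shown, yet a 1.9-fold lower number from compound 2 to compound 3 (0.29 log units; within the scatter), so the two cannot be told apart. Compound 4 `Cc1nc2c(cnn2-c2cccc(Cl)c2)c(=O)n1-c1ccc(Cl)cc1` differs from compound 3 in one place: chloro in place of methyl on an aromatic carbon. Among the measured compounds shown here, no measured step exchanges one aryl substituent for another; the step from compound 3 to compound 4 is therefore expected to be small, a 1.1-fold lower number from compound 3 to compound 4 (0.02 log units; within the scatter). Compound 4 is estimated at 170 nM, between 50 nM and 600 nM in this assay.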

Compound 4, half-maximal inhibitory concentration: 220 nM
Compound 4: the middle estimate sits 1.3-fold (0.11 log units) below what was measured; the measured number falls inside the stated range.
By their numbers in this assay, from the lowest: compounds 3, 4 and 2 (each within the scatter of the next). At a limit, above all of these: compound 1.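

Chloro and methyl on this aromatic carbon cannot be told apart (a 1.2-fold higher number from compound 3 to compound 4 (0.09 log units; within the scatter)), so the new group gives no readable change at this position. Nor does the 3-chlorophenyl group separate from the 2-methylphenyl group (a 1.6-fold lower number from compound 2 to compound 4 (0.20 log units; within the scatter)). A third aryl compound also lies far from compound 1, whose value is a limit (an at least 450-fold lower number from compound 1 to compound 4 (2.65 log units; beyond the scatter)). How an amine, a carboxylic acid or a longer chain on that aromatic carbon would compare remains open, and nothing shown here gives a reason for these results.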